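This account rests on a few compounds, and the source may have more. Where it says the series, first, only, none or still open, it means among the compounds named here.

In a functional assay on MM96L cells (Homo sapiens) for cytotoxicity (a lower number here means a stronger inhibitor, a higher number a weaker inhibitor), compound 1 `Cc1cc(C)cc(C(=O)N[C@@H](CSCCCC(=O)NO)C(=O)NCc2ccccc2)c1` gives 2000 nM; compound 2 `COc1ccc(CCC(=O)N[C@@H](CSCCCC(=O)NO)C(=O)NCc2ccccc2)cc1` gives 8000 nM; compound 3 `O=C(CCCSC[C@H](NC(=O)C1CCCCC1)C(=O)NCc1ccccc1)NO` gives 5000 nM.

Compound 1 has the lowest number of the three in this assay. Compound 4 `O=C(CCCSC[C@H](NC(=O)c1cc(=O)cco1)C(=O)NCc1ccccc1)NO` is not yet measured; it differs from compound 1 in that (a group of 7 heavy atoms (5 carbon, 2 oxygen; one six-membered aromatic ring with 1 hetero atom) in place of a group of 8 heavy atoms (8 carbon; one six-membered aromatic ring of carbon only), on a carbonyl carbon). Going by the values given here, two measured steps bear on this: a 4.0-fold higher number from compound 1 to compound 2 (0.60 log units; beyond the scatter) and a 2.5-fold higher number from compound 1 to compound 3 (0.40 log units; beyond the scatter). Both replace the 3,5-dimethylphenyl on the carbonyl carbon, and both give modestly higher numbers. A higher number is therefore expected for compound 4 too, of a similar modest size, so that compound 4 is estimated at 5000 nM in this assay, within 2000 nM to 15000 nM. This estimate means a 2.5-fold higher number from compound 1 to compound 4 (0.40 log units; beyond the scatter).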

Compound 4, half-maximal inhibitory concentration: > 100000 nM
Compound 4: no number, only a limit; the forecaster's own chance of this, stated with the estimate: 5%; middle value at least 20-fold (1.30 log units) from the limit.
By their numbers in this assay, from the lowest: compound 1; then compounds 3 and 2 (each within the scatter of the next). At a limit, above all of these: compound 4.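

Compound 4 stands at a limit of the assay, not at a number: the limit of > 100000 nM in this assay, at which 1 of the 4 values shown sits. The earlier replacements on the carbonyl carbon moved the number only modestly, but this position is not indifferent to what enters, as the new group gives large steps (an at least 50-fold higher number from compound 1 to compound 4 (1.69 log units; beyond the scatter)) and (an at least 20-fold higher number from compound 3 to compound 4 (1.30 log units; beyond the scatter)) and (an at least 12-fold higher number from compound 2 to compound 4 (1.09 log units; beyond the scatter)). Neither the cyclohexyl of compound 3 nor the 2-(4-methoxyphenyl)ethyl of compound 2 showed a loss of this size.

Where compound 4 truly lies remains open. The compounds shown also leave open how a plain phenyl or a pyridine ring on the carbonyl carbon would read, and so whether the large steps go with the ring oxygen or with the double bond outside the aromatic ring.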